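This account rests on a few compounds, and the source may have more. Where it says the series, first, only, none or still open, it means among the compounds named here.

Of the compounds shown here, three built on a shared core have been tested in an ADME assay for permeability, using PAMPA, at pH 7.4; a lower number here means that the compound crosses the layer more slowly, a higher number that the compound crosses the layer faster. Compound 1 `Cc1cc(NC(=O)Nc2ccc(F)c(F)c2)c2ccccc2n1` gives 478 10^-6 cm/s in this assay. Compound 2 `Cc1cc(NC(=O)Nc2ccc(F)cc2)c2ccccc2n1` gives 801 10^-6 cm/s in this assay. Compound 3 `Cc1cc(NC(=O)Nc2ccccc2F)c2ccccc2n1` gives 817 10^-6 cm/s in this assay. Compound 1 differs from compound 2 by one change, (fluoro in place of hydrogen on an aromatic carbon), and that change gives a 1.7-fold lower number from compound 2 to compound 1 (0.22 log units; within the scatter). Compound 2 and compound 3 have the same atoms joined differently, (2-fluorophenyl in place of 4-fluorophenyl on an amide-type nitrogen), and that change gives a 1.0-fold higher number from compound 2 to compound 3 (0.01 log units; within the scatter). None of these three values can be ranked against the others on this evidence.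

Compound 4 `Cc1cc(NC(=O)Nc2cc(F)ccc2F)c2ccccc2n1` has not yet been measured. It differs from compound 3 by fluoro in place of hydrogen on an aromatic carbon. Among the measured compounds shown here, this is the same kind of change as the one from compound 2 to compound 1, but not the same: in compound 1 the entering fluoro sits on an aromatic carbon that is ortho to a fluoro group and meta to a large group, whereas in compound 4 it sits on an aromatic carbon that is meta to a large group and para to a fluoro group, and the two cores also differ as just described. Because the earlier change gave a 1.7-fold lower number from compound 2 to compound 1 (0.22 log units; within the scatter), the step from compound 3 to compound 4 is expected to be a 1.4-fold lower number from compound 3 to compound 4 (0.13 log units; within the scatter), small and of uncertain direction. Compound 4 is therefore estimated at 600 10^-6 cm/s, most likely falling between 350 10^-6 cm/s and 1000 10^-6 cm/s.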

Compound 4, apparent permeability: 541 10^-6 cm/s
Estimate against measurement, compound 4: 1.1-fold (0.04 log units) above; the range from low to high includes it.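

In this assay, fluoro in place of hydrogen on an aromatic carbon gives a 1.5-fold lower number from compound 3 to compound 4 (0.18 log units; within the scatter), which is a step too small to be told apart from repeat measurements. Set beside the earlier case of this change, the new step agrees with it as closely as two such steps can be expected to: the same change on two cores in this assay, a 1.7-fold lower number (0.22 log units; within the scatter) from compound 2 to compound 1 and a 1.5-fold lower number (0.18 log units; within the scatter) from compound 3 to compound 4, 1.1-fold (0.05 log units) apart, within the scatter of two such steps. So across these two cores the change can be carried over without a surprise in this assay, but the agreement is between two small steps, and it does not show that the change has a real size of its own, or that it would behave alike on a third core, while the entering fluoro also sits at a different place on each core, so core and place cannot be separated here.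

The compounds shown vary only in fluoro groups on one ring, so what the same position would do with a group of another kind, such as an amine, a carboxylic acid or a longer chain, stays open. Also open is whether any change in this series would give a step beyond the scatter in this assay, since every step shown lies within it.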